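A few compounds are considered here, and "the series" means these few. Any claim that something is new, unique, unknown or untested is made for them only; others in the source may bear on it.

Measured so far:
In a functional assay on HL-60 cells (Homo sapiens) for inhibition (on this read-out higher numbers stand for weaker inhibition and lower numbers for stronger inhibition), compound 1 `COc1ccc(-c2cc(=O)n(CC(C)C)nc2-c2ccc(OC)cc2)cc1` gives > 100000 nM, a limit of the assay rather than a number.
In this assay compound 2 `C=CCn1nc(-c2ccc(OC)cc2)c(-c2ccc(OC)cc2)cc1=O` gives > 100000 nM, again a limit rather than a number.
In this assay compound 3 `COc1ccc(-c2cc(=O)n(C(C)C)nc2-c2ccc(OC)cc2)cc1` gives 1320 nM.

Compound 3 thus stands as the only number shown; the other two values sit at the limit of > 100000 nM in this assay, at which 2 of the 3 values shown sit. Compound 4 `COc1ccc(-c2cc(=O)n(CC3CC3)nc2-c2ccc(OC)cc2)cc1` differs from compound 3 in one place: cyclopropylmethyl in place of isopropyl on an aromatic nitrogen. Among the measured compounds shown here, two measured steps bear on this change, an at least 75-fold lower number from compound 1 to compound 3 (1.87 log units; beyond the scatter) and an at least 75-fold lower number from compound 2 to compound 3 (1.87 log units; beyond the scatter), both large, while a step that the two limits leave unreadable from compound 1 to compound 2 cannot be read. Cyclopropylmethyl resembles the isobutyl of compound 1 more than the isopropyl of compound 3, so a large rise in the number is expected, a 23-fold higher number from compound 3 to compound 4 (1.36 log units; beyond the scatter). Compound 4 is therefore estimated at 30000 nM, with a likely range from 3000 nM to 150000 nM.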

Compound 4, half-maximal inhibitory concentration: 1800 nM
Beside the measured number, compound 4's estimate is 17-fold (1.22 log units) above it; measured number below the stated range.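

In this assay the swap of isopropyl for cyclopropylmethyl on the aromatic nitrogen gives a 1.4-fold higher number from compound 3 to compound 4 (0.13 log units; within the scatter) and leaves the two compounds level. The cyclopropyl end of the chain sets compound 4 apart from its neighbours, with an at least 55-fold lower number from compound 1 to compound 4 (1.74 log units; beyond the scatter) against isobutyl and an at least 55-fold lower number from compound 2 to compound 4 (1.74 log units; beyond the scatter) against allyl, so a saturated chain carbon on this nitrogen does not by itself abolish inhibition. Compound 1 and compound 2 enter those steps as limits, not numbers: the limit of > 100000 nM in this assay, at which 2 of the 4 values shown sit. As far as these compounds go, whether a larger ring such as cyclobutylmethyl, or a chain ending in an amine, keeps this inhibition remains open.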